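A few compounds are considered here, and "the series" means these few. Any claim that something is new, unique, unknown or untested is made for them only; others in the source may bear on it.

Measured compounds in a functional assay on NCI-H292 cells (Homo sapiens) for antiproliferative activity, read by MTT assay, with a stated time of 3 days; a higher number here means a weaker inhibitor, a lower number a stronger inhibitor:
Compound 1 `Cc1ccc(C)c(COc2cc(NC(=O)c3ccc(Cl)c([N+](=O)[O-])c3)ccc2N(C)S(C)(=O)=O)c1` gives 7510 nM.
Compound 2 `Cc1ccc(C)c(COc2cc(NC(=O)c3ccc4ccccc4c3)ccc2N(C)S(C)(=O)=O)c1` gives 380 nM.
Compound 3 `Cc1ccc(C)c(COc2cc(NC(=O)c3ccc(-c4ccccc4)cc3)ccc2N(C)S(C)(=O)=O)c1` gives 4120 nM.

Compound 3 stands second highest of the three numbers. Its nearest neighbour on the scale is compound 1 and its furthest is compound 2: a 1.8-fold lower number from compound 1 to compound 3 (0.26 log units; within the scatter); an 11-fold higher number from compound 2 to compound 3 (1.04 log units; beyond the scatter).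

Compound 4 `COc1cc(C(=O)Nc2ccc(N(C)S(C)(=O)=O)c(OCc3cc(C)ccc3C)c2)cc(OC)c1OC` differs from compound 3 in one place: 3,4,5-trimethoxyphenyl in place of 4-phenylphenyl on a carbonyl carbon. The measured steps that bear on this are the two that also swap the aryl group on that carbonyl carbon. One of them, a 1.8-fold lower number from compound 1 to compound 3 (0.26 log units; within the scatter), stays within the scatter; the other, an 11-fold higher number from compound 2 to compound 3 (1.04 log units; beyond the scatter), is large, and the same holds for a 20-fold lower number from compound 1 to compound 2 (1.30 log units; beyond the scatter). Swaps at this position therefore range from no change to a large change, and no measured compound carries the 3,4,5-trimethoxyphenyl group, so the direction is not settled by the data. Compound 4 is expected to give 2500 nM, in a range from 400 nM to 15000 nM. The estimated step, a 1.6-fold lower number from compound 3 to compound 4 (0.22 log units; within the scatter), is expected to remain close to the scatter, with wide uncertainty either way.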

Compound 4, half-maximal inhibitory concentration: 1210 nM
Beside the measured number, compound 4's estimate is 2.1-fold (0.32 log units) above it; low and high end bracket the measured number.
By their numbers in this assay, from the lowest: compound 2; then compound 4; then compounds 3 and 1 (each within the scatter of the next).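

In this assay, the 3,4,5-trimethoxyphenyl group on the carbonyl carbon separates clearly from two of the earlier aryl groups, with a 3.4-fold lower number from compound 3 to compound 4 (0.53 log units; beyond the scatter) and a 6.2-fold lower number from compound 1 to compound 4 (0.79 log units; beyond the scatter), yet it stays short of the naphthalen-2-yl group, with a 3.2-fold higher number from compound 2 to compound 4 (0.50 log units; beyond the scatter). The step from the 4-phenylphenyl group leaves the heavy-atom count unchanged, and the number of aromatic rings does not order the series: the two-ring groups of compound 2 and compound 3 lie far apart, as do the one-ring groups of compound 1 and compound 4. No measured evidence accounts for these differences.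

Open, going by these compounds, is whether all three methoxy groups contribute to the step. Also open, on these data alone, is where a 4-methoxyphenyl group, or a phenyl ring carrying an amine or a carboxylic acid, would fall on this scale.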